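The source may hold more compounds than are shown below. What is called first, only, known or untested is meant among the compounds shown, and "the series" means these compounds.

Measured compounds in a functional assay on A549 cells (Homo sapiens) for antiproliferative activity, read by MTT assay, with a stated time of 72 h; on this read-out higher numbers stand for weaker inhibition and lower numbers for stronger inhibition:
- compound 1, `CCCCOC1=C(C(=O)c2ccccc2)C(c2ccc(Br)cc2)N(CCCn2ccnc2)C1=O`: 18500 nM
- compound 2, `CCOc1ccc(NC2=C(C(=O)c3ccccc3)C(c3ccc(Br)cc3)N(CCCn3ccnc3)C2=O)cc1`: 20200 nM
- compound 3, `O=C(C1=C(Nc2ccc(F)cc2)C(=O)N(CCCn2ccnc2)C1c1ccc(Br)cc1)c1ccccc1`: 27400 nM

Compound 1 gives the lowest of the three numbers in this assay, but its neighbours sit close: the step of a 1.1-fold higher number from compound 1 to compound 2 (0.04 log units; within the scatter) and the step of a 1.5-fold higher number from compound 1 to compound 3 (0.17 log units; within the scatter) both stay within the scatter, as does the step of a 1.4-fold higher number from compound 2 to compound 3 (0.13 log units; within the scatter) between the two arylamino compounds. So far, then, nothing in this set moves the read-out beyond the usual spread.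

Compound 4, `O=C(C1=C(Nc2ccc(Cl)cc2)C(=O)N(CCCn2ccnc2)C1c1ccc(Br)cc1)c1ccccc1`, has not yet been measured in this assay. Its change from compound 1 is (4-chlorophenyl)amino in place of butoxy on a double-bonded ring carbon. The two measured steps that bear on it are the exchange of butoxy for an arylamino group, a 1.1-fold higher number from compound 1 to compound 2 (0.04 log units; within the scatter) and a 1.5-fold higher number from compound 1 to compound 3 (0.17 log units; within the scatter), and the swap of one para substituent on that aryl ring for another, a 1.4-fold higher number from compound 2 to compound 3 (0.13 log units; within the scatter); none of them left the scatter. For the measured compounds named here, a chloro group in that position has no direct precedent here, so the expectation rests on the shared arylamino pattern. The expected step of a 1.3-fold higher number from compound 1 to compound 4 (0.11 log units; within the scatter) is therefore small, leaning if anything toward a slightly higher number. Compound 4 is estimated at 24000 nM, with a range from 12000 nM to 50000 nM.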

Compound 4, half-maximal inhibitory concentration: 30000 nM
For compound 4 the middle estimate is 1.3-fold (0.10 log units) below the measured one; measured number inside the range.
By their numbers in this assay, from the lowest: compounds 1, 2, 3 and 4 (each within the scatter of the next).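

In this assay, a chloro-bearing arylamino group at the double-bonded ring carbon remains within the scatter of the butoxy compound (a 1.6-fold higher number from compound 1 to compound 4 (0.21 log units; within the scatter)), so this position has now taken a third arylamino group without leaving that spread. The aromatic substituent does not separate the compounds either: chloro for fluoro (a 1.1-fold higher number from compound 3 to compound 4 (0.04 log units; within the scatter)) and chloro for ethoxy (a 1.5-fold higher number from compound 2 to compound 4 (0.17 log units; within the scatter)) both stay within the scatter, and fluoro, chloro and ethoxy cannot be told apart on this read-out. No supporting measurement bears on this flat picture.

Still open, going by these compounds, is whether any group at this place can move the read-out beyond the scatter, for example a morpholine in place of the arylamino group or a carboxylic acid on its aryl ring. On these data alone, the 4-bromophenyl, benzoyl and 3-(1H-imidazol-1-yl)propyl groups are shared by all four compounds, so their contributions remain unknown.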